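A few compounds are considered here, and "the series" means these few. Any claim that something is new, unique, unknown or untested is made for them only; others in the source may bear on it.

Working notes on the series. Compound 1, `CCn1c(=O)c2nc(-c3cnn(Cc4cccc(F)c4)c3)[nH]c2n(CC)c1=O`, is the reference point: in an assay on CHO cells for displacement of a labelled ligand from adenosine receptor A1 (Homo sapiens) (on this read-out higher numbers stand for weaker inhibition and lower numbers for stronger inhibition), compound 1 gives 380 nM. Compound 2, `CCCn1c(=O)c2nc(-c3cnn(Cc4cc(C(F)(F)F)ccc4Cl)c3)[nH]c2n(CCC)c1=O`, carries propyl chains on the shared core instead of the ethyl chains of compound 1 and a different substituted ring on the saturated chain carbon bound to the aromatic nitrogen; in this assay compound 2 gives 1200 nM. Within the data shown here, of the two numbers measured so far, compound 2 has the higher one, and the gap to compound 1 lies beyond the usual scatter. Among the measured compounds shown here, no single-point step between measured compounds is available, so the two values can only be set side by side.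

The next compound, compound 3, `CCCn1c(=O)c2nc(-c3cnn(Cc4ccccc4C(F)(F)F)c3)[nH]c2n(CCC)c1=O`, keeps the propyl chains of compound 2 and differs from it in one place: 2-(trifluoromethyl)phenyl in place of 2-chloro-5-(trifluoromethyl)phenyl on a saturated chain carbon bound to an aromatic nitrogen. With nothing in the set to gauge this exact change, the step from compound 2 to compound 3 in this assay is expected to be modest, a 1.5-fold lower number from compound 2 to compound 3 (0.18 log units; within the scatter), toward a lower number, and possibly not beyond the scatter. For compound 3 the estimate in this assay is 800 nM, with a range from 300 nM to 2500 nM.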

Compound 3, inhibition constant: 44 nM
Beside the measured number, compound 3's estimate is 18-fold (1.26 log units) above it; measured number outside the range, below it.
By their numbers in this assay, from the lowest: compound 3; then compound 1; then compound 2.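

At the saturated chain carbon bound to an aromatic nitrogen, 2-(trifluoromethyl)phenyl in place of 2-chloro-5-(trifluoromethyl)phenyl gives, in this assay, a 27-fold lower number from compound 2 to compound 3 (1.44 log units; beyond the scatter), a large step toward stronger inhibition. Among these compounds, this is the first single-place reading: with the propyl chains held constant, the substitution on this ring alone moves the value well beyond the scatter, which the two-place gap between the earlier compounds could not show. The change removes the chlorine and also alters the number that locates the trifluoromethyl group in the name, and no measured evidence on the compounds bears on the reason for the size of the step.

The compounds shown do not separate the loss of the chlorine from the different location of the trifluoromethyl group; a phenyl without substituents, a 2-chlorophenyl or a 3-(trifluoromethyl)phenyl at this place would help to divide the two contributions. On these data alone, it also stays open whether 2-(trifluoromethyl)phenyl would give a step of similar size with the ethyl chains of compound 1 on the shared core.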